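The compounds below may be only part of what the source reports. "The series", "measured", "known", "first", "only" and "open" are said of these compounds alone.

Measured so far in an in vitro assay on BTI-TN-5B1-4 cells for inhibition of Amine oxidase [flavin-containing] A (Homo sapiens), read by fluorescence; a lower number here means a stronger inhibitor, a higher number a weaker inhibitor:

compound 1 `CCc1ccc(NC(=O)c2cc3ccccc3oc2=O)cc1`: 15700 nM
compound 2 `O=C(Nc1ccc(F)cc1)c1cc2ccccc2oc1=O`: 13100 nM

These two values lie within the scatter of each other, the step being a 1.2-fold lower number from compound 1 to compound 2 (0.08 log units; within the scatter), so on the numbers at hand compound 2 is not distinguished from compound 1. Compound 3 `CS(=O)(=O)c1ccc(NC(=O)c2cc3ccccc3oc2=O)cc1` is not yet measured; it differs from compound 2 by methylsulfonyl in place of fluoro on an aromatic carbon. Among the compounds with values here, the only step that bears on this place, from compound 1 to compound 2, stayed within the scatter, so no change beyond the scatter is expected in this assay. Compound 3 is therefore estimated at 14000 nM, with a range of 5000 nM to 40000 nM, an expected step of a 1.1-fold higher number from compound 2 to compound 3 (0.03 log units; within the scatter).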

Compound 3, half-maximal inhibitory concentration: 9330 nM
Beside the measured number, compound 3's estimate is 1.5-fold (0.18 log units) above it, within the range that was stated.
By their numbers in this assay, from the lowest: compounds 3, 2 and 1 (each within the scatter of the next).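

In this assay, methylsulfonyl brings four heavy atoms and two hydrogen-bond acceptors to this aromatic carbon, where fluoro has one heavy atom and no acceptor, and the result is a 1.4-fold lower number from compound 2 to compound 3 (0.15 log units; within the scatter). Set against ethyl, the same group gives a 1.7-fold lower number from compound 1 to compound 3 (0.23 log units; within the scatter), so this much larger swap still leaves all three compounds unseparated at this place. No measurement at hand speaks to why the number responds so little here.

The compounds shown leave open whether an amine or a carboxylic acid at this place would move the number beyond the scatter.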